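The source may hold more compounds than are shown below. What is called first, only, known or untested is meant among the compounds shown, and "the series" means these compounds.

Measured compounds:
compound 1 `CCCCCCc1ccc2[nH]c(-c3ccc(OC)cc3)c(C3=C(Br)C(=O)NC3=O)c2c1` — "not determined" (no result reported) in a physicochemical assay for lipophilicity; a lower number here means a more polar compound, a higher number a more lipophilic compound
compound 2 `CCOc1ccc2[nH]c(-c3cccc(OC)c3)c(C3=C(Br)C(=O)NC3=O)c2c1` — 2.97
compound 3 `CCCCc1ccc2[nH]c(-c3cccc(OC)c3)c(C3=C(Br)C(=O)NC3=O)c2c1` — 3.81

Compound 3 stands highest of the two numbers in this assay; its nearest neighbour is compound 2, and the step of a number 0.84 log units higher from compound 2 to compound 3 (beyond the scatter) lies beyond the scatter, a butyl in place of ethoxy on an aromatic carbon. Compound 1 carries a hexyl on the same core together with the methoxy group in its other position, but no number is reported for it.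

Compound 4 `CCCCCCc1ccc2[nH]c(-c3cccc(OC)c3)c(C3=C(Br)C(=O)NC3=O)c2c1` is the next entry to be measured. Relative to compound 3 the change is ethyl in place of hydrogen on a saturated chain carbon, four bonds along the chain from an aromatic carbon — ethyl in place of hydrogen on a saturated chain carbon, four bonds along the chain from an aromatic carbon; read one bond further out, the butyl of compound 3 becomes the hexyl of compound 4.

Going by the values given here, only one measured step bears on this: a number 0.84 log units higher from compound 2 to compound 3 (beyond the scatter), which exchanged an oxygen-linked group for a longer carbon chain and went up. The present change is a pure chain extension, so a rise beyond the scatter is expected, of roughly comparable size. The step from compound 3 to compound 4 is therefore estimated as a number 0.99 log units higher from compound 3 to compound 4 (beyond the scatter). Compound 4 is expected to give 4.8 in this assay, with a range from 4.3 to 5.3.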

Compound 4, partition coefficient: 4.26
Compound 4: middle estimate off by 0.54 log units, on the high side, and the stated range ends above it.
By their numbers in this assay, from the lowest: compound 2; then compound 3; then compound 4.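

In this assay the chain on this aromatic carbon can be taken past butyl to hexyl and the number still rises, with a number 0.45 log units higher from compound 3 to compound 4 (beyond the scatter) for ethyl in place of hydrogen on a saturated chain carbon, four bonds along the chain from an aromatic carbon. Going by these compounds alone, this is the first step that changes the length of a carbon chain alone, since a number 0.84 log units higher from compound 2 to compound 3 (beyond the scatter) also exchanged the oxygen-linked ethoxy group, and the whole exchange of ethoxy for hexyl gives a number 1.29 log units higher from compound 2 to compound 4 (beyond the scatter), leaving compound 4 highest of the three numbers. No separate measurement bears on why the added ethyl produces a step of this size.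

From the compounds shown here alone, whether the number keeps rising with a longer chain such as octyl, or how an amine or a carboxylic acid at the end of the chain would read, remains open. Compound 1 carries the same hexyl with its methoxy group placed differently and gives "not determined" (no result reported), so the effect of moving that methoxy group cannot be read from it.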